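Compound 3 and a second ring substituent

A few compounds are considered here, and "the series" means these few. Any claim that something is new, unique, unknown or untested is made for them only; others in the source may bear on it.

Among the compounds with values here, in a functional assay on B16-F0 cells (Mus musculus) for inhibition, read by CCK-8 assay, with a stated time of 48 h (on this read-out lower numbers stand for stronger inhibition and higher numbers for weaker inhibition), compound 3 `COc1cc(-c2ccnc3cc(-c4cccc(C)c4)nn23)cc(OC)c1OC` gives 2220 nM, the highest of the three numbers measured so far and therefore the weakest result. Compound 1 `COc1cc(-c2ccnc3cc(-c4ccc(C)c(C)c4)nn23)cc(OC)c1OC` gives 391 nM, and compound 2 `COc1cc(-c2ccnc3cc(-c4ccc5c(ccn5C)c4)nn23)cc(OC)c1OC` gives 48 nM. These compounds share a core and differ only in the aromatic group attached to it. Compound 4 `COc1ccc(-c2cc3nccc(-c4cc(OC)c(OC)c(OC)c4)n3n2)cc1F` keeps the core and changes that group: 3-fluoro-4-methoxyphenyl in place of 3-methylphenyl on an aromatic carbon.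

Within the data shown here, two measured steps bear on this change. The closest comparison is with the 3,4-dimethylphenyl group of compound 1, which, like the incoming 3-fluoro-4-methoxyphenyl group, has two substituents on its ring. Removing one methyl from that ring gave a 5.7-fold higher number from compound 1 to compound 3 (0.75 log units; beyond the scatter), a modest step. Exchanging the whole group gave a 46-fold higher number from compound 2 to compound 3 (1.67 log units; beyond the scatter), a large step showing how far the number can move at this place. Among the measured compounds shown here, no measured compound has a fluorine, and none has a methoxy on this ring, so the comparison with compound 1 is only approximate. A modest improvement is therefore expected in this assay, and the expected step is a 6.3-fold lower number from compound 3 to compound 4 (0.80 log units; beyond the scatter). For compound 4, the estimated value is 350 nM, with an expected range from 70 nM to 1800 nM.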

Compound 4, half-maximal inhibitory concentration: 3950 nM
Compound 4: middle estimate off by 11-fold (1.05 log units), on the low side, outside the stated range (above it).
By their numbers in this assay, from the lowest: compound 2; then compound 1; then compounds 3 and 4 (each within the scatter of the next).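

In this assay, putting 3-fluoro-4-methoxyphenyl in place of 3-methylphenyl gives a 1.8-fold higher number from compound 3 to compound 4 (0.25 log units; within the scatter) and so leaves compounds 3 and 4 indistinguishable, which shows that this change does not reproduce the gain seen with the extra methyl of compound 1. The same group in place of 3,4-dimethylphenyl gives a 10-fold higher number from compound 1 to compound 4 (1.00 log units; beyond the scatter) and thus shows that having two substituents on this ring is not enough on its own: which two they are matters here. In place of 1-methyl-1H-indol-5-yl it gives an 82-fold higher number from compound 2 to compound 4 (1.92 log units; beyond the scatter) and this widens the range seen at this position, with compound 2 still holding the lowest number of the four.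

No measurement here explains why this pair of substituents fails to match the two methyl groups. The compounds shown leave open what the fluorine and the methoxy each do alone, and whether a phenyl ring carrying an amine or a carboxylic acid would move the number in either direction.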